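The source may hold more compounds than are shown below. What is called first, only, known or untested is meant among the compounds shown, and "the series" means these compounds.

Compound 1 `COc1ccc2[nH]c(C(=O)N3CC(=O)N(Cc4ccccc4)[C@@H](CN4CCC(C)CC4)C3)cc2c1`: 93100 nM
Compound 2 `COc1ccc2[nH]c(C(=O)N3CC(=O)N(Cc4ccc[nH]4)[C@@H](Cc4ccccc4)C3)cc2c1`: 38400 nM
Compound 3 `COc1ccc2[nH]c(C(=O)N3CC(=O)N(c4ccccc4)[C@@H](Cc4ccccc4)C3)cc2c1`: 36100 nM

In a physicochemical assay for solubility, read by spectrophotometry, in phosphate buffer, with a stated time of 2 h, at pH 7.4 (on this read-out lower numbers stand for lower solubility and higher numbers for higher solubility), compound 1 gives the highest of the three numbers, with compound 2 and compound 3 both lower. Among the compounds with values here, the only single-site step among the measured compounds, a 1.1-fold lower number from compound 2 to compound 3 (0.03 log units; within the scatter), concerns the group on the amide-type nitrogen in the ring, not the position altered here. Compound 4 `COc1ccc2[nH]c(C(=O)N3CC(=O)N(Cc4ccccc4)[C@@H](CN4CCC5(CCCC5)CC4)C3)cc2c1` differs from compound 1 by a group of 10 heavy atoms (9 carbon, 1 nitrogen; one five-membered non-aromatic ring of carbon only, one six-membered non-aromatic ring with 1 hetero atom) in place of a group of 7 heavy atoms (6 carbon, 1 nitrogen; one six-membered non-aromatic ring with 1 hetero atom), on a saturated chain carbon bound to a saturated ring carbon. Within the data shown here, no measured step touches this position, so the expectation for compound 4 leans on compound 1 alone and is set somewhat lower, as a 2.3-fold lower number from compound 1 to compound 4 (0.37 log units; beyond the scatter). Compound 4 is therefore estimated at 40000 nM in this assay, with a range from 12000 nM to 120000 nM.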

Compound 4, solubility: 5000 nM
Beside the measured number, compound 4's estimate is 8.0-fold (0.90 log units) above it; measured number outside the range, below it.
By their numbers in this assay, from the lowest: compound 4; then compounds 3 and 2 (each within the scatter of the next); then compound 1.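

In this assay the position on the saturated chain carbon proves sensitive: the group bearing the five-membered carbon ring, in place of 4-methylpiperidin-1-yl, gives a 19-fold lower number from compound 1 to compound 4 (1.27 log units; beyond the scatter). This single step at the position is far larger than the one at the amide-type nitrogen, and it leaves compound 4 with the lowest number of the four. Nothing measured here explains the fall.

One step cannot say whether the five-membered carbon ring itself or simply the larger group goes with the fall. As far as these compounds go, how morpholin-4-yl or a piperidine carrying a carboxylic acid would read at this place also remains open.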